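Benzylic methoxy substitution in an antiproliferative triazole series

The source may hold more compounds than are shown below. What is called first, only, known or untested is meant among the compounds shown, and "the series" means these compounds.

Compound 2 `COc1ccc(Cn2cc(CNC(=O)c3cn(-c4ccccc4)nc3-c3ccc(Cl)cc3)nn2)cc1` holds the lowest number of the two measured in a functional assay on MCF7 cells (Homo sapiens) for antiproliferative activity, read by sulforhodamine B assay, with a stated time of 48 h (a higher number here means a weaker inhibitor of growth, a lower number a stronger inhibitor of growth), where compound 2 gives 8000 nM. Its neighbour compound 1 `O=C(NCc1cn(Cc2ccc(Cl)cc2)nn1)c1cn(-c2ccccc2)nc1-c1ccc(Cl)cc1` gives 28800 nM; the step of a 3.6-fold lower number from compound 1 to compound 2 (0.56 log units; beyond the scatter) is the only one measured, and it bears only loosely on compound 3 `COc1cc(Cn2cc(CNC(=O)c3cn(-c4ccccc4)nc3-c3ccc(Cl)cc3)nn2)cc(OC)c1OC`, which differs from compound 2 by 3,4,5-trimethoxyphenyl in place of 4-methoxyphenyl on a saturated chain carbon bound to an aromatic nitrogen. For the measured compounds named here, since that single step was modest and no measured pair tests added methoxy groups, the expected step of a 1.6-fold lower number from compound 2 to compound 3 (0.20 log units; within the scatter) is small, possibly within the scatter. Compound 3 is therefore estimated at 5000 nM, ranging from 1500 nM to 16000 nM.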

Compound 3, concentration for 50% growth inhibition: 2500 nM
Compound 3: middle estimate off by 2.0-fold (0.30 log units), on the high side; the measured number falls inside the stated range.
By their numbers in this assay, from the lowest: compound 3; then compound 2; then compound 1.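

In this assay, the place on a saturated chain carbon bound to an aromatic nitrogen responds to further methoxy groups, not only to the first one: 3,4,5-trimethoxyphenyl in place of 4-methoxyphenyl gives a 3.2-fold lower number from compound 2 to compound 3 (0.51 log units; beyond the scatter), a step beyond the scatter. Taken together, 3,4,5-trimethoxyphenyl in place of 4-chlorophenyl gives a 12-fold lower number from compound 1 to compound 3 (1.06 log units; beyond the scatter), a large step where the earlier one was modest.

On these data alone, how the three methoxy groups share this drop stays open, as does how a hydroxyl or a dimethylamino group on the same ring would read. Nothing shown here gives a reason for these steps.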